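A few compounds are considered here, and "the series" means these few. Any claim that something is new, unique, unknown or untested is made for them only; others in the source may bear on it.

Measured so far in a functional assay on FaDu cells (Homo sapiens) for cytotoxicity, read by MTT assay, with a stated time of 72 h; on this read-out higher numbers stand for lower toxicity in this test and lower numbers for higher toxicity in this test:
Compound 1 `CCn1cc(C(=O)C(=O)Nc2ccc(OC)nc2)c2ccccc21` gives 219 nM.
Compound 2 `COc1ccc(NC(=O)C(=O)c2cn(C(C)C)c3cccc(OC)c23)cn1` gives 7780 nM.
Compound 3 `COCCn1cc(C(=O)C(=O)Nc2ccc(OC)nc2)c2cccnc21` gives 27 nM.

Among these three numbers compound 1 stands second highest. Compound 3 shows the nearest value, a lower number that lies beyond the usual scatter, so compound 3 is the more toxic of the two in this assay. Compound 2 shows a higher number, also beyond the scatter, making it the least toxic of the three.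

Compound 4 `COc1ccc(NC(=O)C(=O)c2cn(CCOC(C)C)c3ccccc23)cn1` has not yet been measured. It differs from compound 1 in one place: isopropoxy in place of hydrogen on a saturated chain carbon, two bonds along the chain from an aromatic nitrogen. For the measured compounds named here, no pair of measured compounds shows exactly this change, so its effect has to be guessed. Compound 3 carries a different chain and a different core, so its lower number cannot be attributed to the chain alone. The step from compound 1 to compound 4 is expected to be small, about a 1.5-fold lower number from compound 1 to compound 4 (0.16 log units; within the scatter), towards a lower number or none beyond the scatter. Compound 4 is therefore estimated at 150 nM, within a range from 40 nM to 600 nM.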

Compound 4, concentration lethal to 50% of the cells: 211 nM
The estimate for compound 4 lay 1.4-fold (0.15 log units) below the measured number; measured number inside the range.
By their numbers in this assay, from the lowest: compound 3; then compounds 4 and 1 (each within the scatter of the next); then compound 2.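

Compound 1 and compound 4 share the same core and differ only in the chain on the aromatic nitrogen, so this pair isolates that one change. In this assay, for the compounds shown here, going from ethyl to 2-isopropoxyethyl gives a 1.0-fold lower number from compound 1 to compound 4 (0.02 log units; within the scatter), so at this position the added isopropoxy leaves the number within the scatter, something the earlier compounds could not show while each differed from the others in more than one place. No supporting measurement bears on the reason for this result.

Still open, from the compounds shown here alone, is whether a different group at the end of this chain, such as an amine or a carboxylic acid, or a much longer chain, would leave the number just as undisturbed. Also open, going by these compounds, is whether the same change would give a similar step on the core of compound 3.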